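This account rests on a few compounds, and the source may have more. Where it says the series, first, only, none or still open, it means among the compounds named here.

Measured in a functional assay on J774 cells (Mus musculus) for cytotoxicity, read by resazurin assay; a higher number here means a weaker inhibitor, a lower number a stronger inhibitor:
- compound 1 `Cc1ccc(-c2ccc(C(O)CCCCCO)cc2)cc1`: 22000 nM
- compound 2 `OCCCCCC(O)c1ccc(-c2ccc(O)cc2)cc1`: 15000 nM
- compound 3 `OCCCCCC(O)c1ccc(-c2ccc(Cl)cc2)cc1`: 17000 nM

Compound 3 stands within the scatter of the other two measured compounds, as a 1.3-fold lower number from compound 1 to compound 3 (0.11 log units; within the scatter) and a 1.1-fold higher number from compound 2 to compound 3 (0.05 log units; within the scatter) show. The next compound, compound 4 `CCOc1ccc(-c2ccc(C(O)CCCCCO)cc2)cc1`, has ethoxy in place of chloro on an aromatic carbon. The third measured swap at this place, a 1.5-fold lower number from compound 1 to compound 2 (0.17 log units; within the scatter), is also within the scatter, so methyl, hydroxy and chloro show no real difference here. None of these steps involves ethoxy, so they are only an indirect guide. The expected step is a 1.1-fold higher number from compound 3 to compound 4 (0.02 log units; within the scatter), nothing beyond the scatter. Compound 4 is expected near 18000 nM, with an estimated range from 9000 nM to 35000 nM.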

Compound 4, half-maximal inhibitory concentration: 14000 nM
Compound 4: middle estimate off by 1.3-fold (0.11 log units), on the high side; measured number inside the range.
By their numbers in this assay, from the lowest: compounds 4, 2, 3 and 1 (each within the scatter of the next).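

In this assay, ethoxy brings three heavy atoms and one hydrogen-bond acceptor where chloro has one heavy atom and none, yet a 1.2-fold lower number from compound 3 to compound 4 (0.08 log units; within the scatter) and a 1.1-fold lower number from compound 2 to compound 4 (0.03 log units; within the scatter) and a 1.6-fold lower number from compound 1 to compound 4 (0.20 log units; within the scatter) all stay within the scatter. Adding ethyl to the oxygen of compound 2 therefore shows no real difference, and this position, para to a large group, has now held four different groups without a real change. No measurement here offers an explanation for this flat result. From the compounds shown here alone, it remains open whether an amine, a carboxylic acid or a longer chain at this place would move the number beyond the scatter.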